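From 3,4-Difluorophenyl to 3,4-Dichlorophenyl: An Expected Flat Step

The source may report more compounds than this note shows. Statements on the series, on what has been measured and on what is new or still open speak of the compounds shown alone.

Compound 2 `Nc1scc(CN2CCN(c3ccc(F)c(F)c3)CC2)c1C(=O)c1ccc(Cl)cc1` and compound 1 `Nc1scc(CN2CCN(c3ccc([N+](=O)[O-])cc3)CC2)c1C(=O)c1ccc(Cl)cc1` share one core and differ only in the group on an amine nitrogen in a ring. In an assay on CHO cells for displacement of a labelled ligand from adenosine receptor A1 (Homo sapiens), read by scintillation counting, with a stated time of 120 min, tested at 10 uM (on this read-out lower numbers stand for less inhibition and higher numbers for more inhibition at the one concentration tested (going by the name of the read-out)), compound 1 gives 1%, and in this assay compound 2 gives 0%. Compound 2 stands at the bottom of the two numbers shown, with compound 1 nearest, the gap being within the scatter. Among the measured compounds shown here, the one measured step, a number 1 percentage points lower from compound 1 to compound 2 (within the scatter), shows that putting 3,4-difluorophenyl in place of 4-nitrophenyl left the read-out essentially unchanged, both compounds sitting near the floor of the scale.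

Compound 3 `Nc1scc(CN2CCN(c3ccc(Cl)c(Cl)c3)CC2)c1C(=O)c1ccc(Cl)cc1` has not yet been measured. It differs from compound 2 by 3,4-dichlorophenyl in place of 3,4-difluorophenyl on an amine nitrogen in a ring. For the measured compounds named here, the only step that bears on this change is a number 1 percentage points lower from compound 1 to compound 2 (within the scatter): a swap of the group on the same ring nitrogen that moved nothing beyond the scatter. Nothing in these two compounds suggests that 3,4-dichlorophenyl would act differently from 3,4-difluorophenyl. The expected step is therefore a number 2 percentage points higher from compound 2 to compound 3 (within the scatter), with no direction beyond the scatter. Compound 3 is estimated at 2%, within 0% to 10%.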

Compound 3, a percentage reported as inhibition, at one concentration (the size of the read-out at that concentration, not a potency): 1%
Compound 3: middle estimate off by 1 percentage points, on the high side, within the range that was stated.
By their numbers in this assay, from the lowest: compounds 2, 1 and 3 (each within the scatter of the next).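

In this assay, the change from two fluorines to two chlorines on the phenyl ring gives a number 1 percentage points higher from compound 2 to compound 3 (within the scatter) and the comparison with the nitro-bearing ring gives no change at the digits printed from compound 1 to compound 3 (within the scatter). This extends what the first pair showed: a third phenyl group on the same amine nitrogen in a ring, now carrying chlorine, also cannot be told apart from the others, and all three numbers lie near the bottom of the scale at the one concentration tested. No measurement shown here offers an explanation for this flat result.

Because every compound shown carries a substituted phenyl ring on this nitrogen, it remains open whether a different kind of group there, such as a benzyl group, an acetyl group or a plain methyl, would give inhibition clear of the scatter. As far as these compounds go, with all three numbers so close to the bottom of the scale, it also remains open whether this nitrogen matters at all for this read-out, or whether changes elsewhere on the shared core, such as to the 4-chlorophenyl ketone, would matter more.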